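A few compounds are considered here, and "the series" means these few. Any claim that something is new, unique, unknown or untested is made for them only; others in the source may bear on it.

Compound 3 `Cc1cc(-c2cc(Cl)cc(Cl)c2)cc(C)c1Nc1ccnc(Nc2ccc(C#N)cc2)n1` sits in an ADME assay on MT4 cells (Homo sapiens) for cytotoxicity, read by MTT assay, with a stated time of 4 days (on this read-out higher numbers stand for lower toxicity in this test and lower numbers for higher toxicity in this test), at 4290 nM, indistinguishable within the scatter from compound 1 `Cc1cc(-c2cccc(F)c2)cc(C)c1Nc1ccnc(Nc2ccc(C#N)cc2)n1`, which gives 4120 nM, and from compound 2 `Cc1cc(-c2cc(F)cc(F)c2)cc(C)c1Nc1ccnc(Nc2ccc(C#N)cc2)n1`, which gives 3910 nM. The change to compound 4 `Cc1ccccc1-c1cc(C)c(Nc2ccnc(Nc3ccc(C#N)cc3)n2)c(C)c1` is 2-methylphenyl in place of 3,5-dichlorophenyl on an aromatic carbon. Among the measured compounds shown here, the steps that bear on it are a 1.0-fold higher number from compound 1 to compound 3 (0.02 log units; within the scatter) and a 1.1-fold higher number from compound 2 to compound 3 (0.04 log units; within the scatter), each a change of the substituents on the pendant phenyl ring; a 1.1-fold lower number from compound 1 to compound 2 (0.02 log units; within the scatter) is likewise within the scatter. Since every exchange on that ring so far left this assay unchanged, compound 4 is expected to give a number about the same, a step of a 1.0-fold lower number from compound 3 to compound 4 (0.02 log units; within the scatter). The estimate for compound 4 is 4100 nM, between 2000 nM and 8500 nM.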

Compound 4, half-maximal cytotoxic concentration: 3820 nM
For compound 4 the middle estimate is 1.1-fold (0.03 log units) above the measured one, within the range that was stated.
By their numbers in this assay, from the lowest: compounds 4, 2, 1 and 3 (each within the scatter of the next).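

In this assay, 2-methylphenyl on this aromatic carbon gives a 1.1-fold lower number from compound 3 to compound 4 (0.05 log units; within the scatter) and a 1.0-fold lower number from compound 2 to compound 4 (0.01 log units; within the scatter) and a 1.1-fold lower number from compound 1 to compound 4 (0.03 log units; within the scatter), so all four compounds lie within the scatter of one another. The earlier compounds shown here carried only fluoro or chloro on the pendant phenyl ring, whereas compound 4 shows that a methyl-bearing phenyl ring without halogen also stays within that scatter. Nothing available explains this flat result. The compounds shown leave open whether a pendant phenyl ring carrying an amine or a carboxylic acid would stay within the same scatter.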